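Cytotoxicity shift on replacing the sulfamoylpiperazinylmethyl arm

The source may hold more compounds than are shown below. What is called first, only, known or untested is meant among the compounds shown, and "the series" means these compounds.

Measured compounds:
compound 1 `Cc1cc(/C=C/C#N)cc(C)c1Oc1nc(Nc2ccc(CN3CCN(S(N)(=O)=O)CC3)cc2)nc2ccsc12` — 145000 nM
compound 2 `Cc1cc(/C=C/C#N)cc(C)c1Oc1nc(Nc2ccc(CN3CCN(S(C)(=O)=O)CC3)cc2)nc2sccc12` — 131000 nM
compound 3 `Cc1cc(/C=C/C#N)cc(C)c1Oc1nc(Nc2ccc(N3CCCC(N)C3)cc2)nc2sccc12` — 4610 nM

In an ADME assay on MT4 cells (Homo sapiens) for cytotoxicity, read by MTT assay, with a stated time of 5 days (a higher number here means that more compound is tolerated, a lower number that less compound is tolerated), compound 1 gives the highest number of the three; compound 2 sits within the scatter of it, while compound 3 lies far lower. Compound 4 `Cc1cc(/C=C/C#N)cc(C)c1Oc1nc(Nc2ccc(N3CCCC(N)C3)cc2)nc2ccsc12` has not yet been measured. It differs from compound 1 as follows: 3-aminopiperidin-1-yl in place of (4-sulfamoylpiperazin-1-yl)methyl on an aromatic carbon.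

Among the measured compounds shown here, one measured step bears directly on this change: a 28-fold lower number from compound 2 to compound 3 (1.45 log units; beyond the scatter). Compound 1 and compound 2 differ only in the ring fusion and a sulfamoyl against a methylsulfonyl group, and their numbers are alike, so the same kind of replacement is expected to act similarly here. A large drop is therefore expected, a 28-fold lower number from compound 1 to compound 4 (1.45 log units; beyond the scatter). Compound 4 is estimated at 5200 nM, with a range of 2000 nM to 13000 nM.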

Compound 4, half-maximal cytotoxic concentration: 3820 nM
Compound 4: middle estimate off by 1.4-fold (0.13 log units), on the high side; measured number inside the range.
By their numbers in this assay, from the lowest: compounds 4 and 3 (each within the scatter of the next); then compounds 2 and 1 (each within the scatter of the next).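

In this assay the replacement brings a 38-fold lower number from compound 1 to compound 4 (1.58 log units; beyond the scatter) and so lowers the number on this aromatic carbon of the core of compound 1 as well, where the group leaving is (4-sulfamoylpiperazin-1-yl)methyl. Compound 4 stands within the scatter of compound 3, so with 3-aminopiperidin-1-yl in place, the two cores give alike numbers. No measurement shown here gives a reason for the drop. The compounds shown leave open whether the drop goes with the amine of the entering group or with the loss of the piperazine arm; a hydroxyl group in place of that amine could separate the two.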